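Methyl for hydroxy on the pyridine ring: the next step

The source may hold more compounds than are shown below. What is called first, only, known or untested is meant among the compounds shown, and "the series" means these compounds.

Among the measured compounds shown here, the series so far holds two compounds. Compound 1 `Cc1cncc(OC[C@@H]2CCN2)c1` carries a methyl on the aromatic ring and in an assay on brain for binding affinity to Neuronal acetylcholine receptor; alpha4/beta2 (Rattus norvegicus), read by radioligand binding (on this read-out lower numbers stand for stronger inhibition and higher numbers for weaker inhibition), compound 1 gives 0.047 nM. Compound 2 `Oc1cncc(OC[C@H]2CCN2)c1` carries a hydroxy at that position and in this assay compound 2 gives 0.088 nM. On the numbers shown, compound 2 stands as the higher of the two, yet its gap to compound 1 lies within the scatter, so the two values cannot be ranked against each other.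

Compound 3 `Cc1cncc(OC[C@H]2CCN2)c1` is the next member to be measured in this assay. The change from compound 2 to compound 3 is methyl in place of hydroxy on an aromatic carbon. For the measured compounds named here, no step between measured compounds is available for this change, so the expectation rests on the values already in hand. The methyl compound 1 sits close to the hydroxy compound 2, so no shift beyond the scatter is expected, and the step from compound 2 to compound 3 is estimated at a 1.0-fold higher number from compound 2 to compound 3 (0.01 log units; within the scatter). For compound 3 in this assay the estimate is 0.09 nM, with a range from 0.03 nM to 0.4 nM.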

Compound 3, inhibition constant: 0.16 nM
Compound 3: middle estimate off by 1.8-fold (0.25 log units), on the low side, within the range that was stated.
By their numbers in this assay, from the lowest: compounds 1, 2 and 3 (each within the scatter of the next, the first and the last beyond it).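

Among the compounds shown here, compound 3 gives the first comparison of methyl and hydroxy at this aromatic carbon with the configuration as drawn held the same, since compounds 1 and 2 differ in both. In this assay the swap of hydroxy, with 1 hydrogen-bond donor and 1 hydrogen-bond acceptor, for methyl, with 0 of each, gives a 1.8-fold higher number from compound 2 to compound 3 (0.26 log units; within the scatter), so the two groups cannot be separated at this position in this configuration. The series also gains its first step beyond the scatter, a 3.4-fold higher number from compound 1 to compound 3 (0.53 log units; beyond the scatter), a modest one that comes from the stereocentre at the saturated ring carbon alone, drawn S in compound 1 and R in compound 3, and that can be assigned to configuration because nothing else separates the pair: the fact that compounds 1 and 3 differ only in the configuration as drawn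

On these data alone, whether hydroxy and methyl also stay within the scatter of each other with the stereocentre drawn S remains open, as a single pair cannot show it. Also open, as far as these compounds go, is how a methoxy, a chlorine or an amine at this aromatic carbon would read in this assay, and whether the configuration step would hold with any of them in place.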